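Amide aryl swaps: from compound 3 to compound 4

A few compounds are considered here, and "the series" means these few. Any claim that something is new, unique, unknown or untested is made for them only; others in the source may bear on it.

The three measured compounds share one core and differ only in the aryl group on the amide carbonyl carbon. Compound 1 `Cc1ccc(C(=O)Nc2cccc(/C=C/C(=O)c3nc4ccccc4[nH]3)c2)cc1` carries 4-methylphenyl there, and in a functional assay on MCF7 cells (Homo sapiens) for antiproliferative activity, read by MTT assay, with a stated time of 48 h (on this read-out higher numbers stand for weaker inhibition and lower numbers for stronger inhibition), compound 1 gives 9690 nM. Compound 2 `O=C(Nc1cccc(/C=C/C(=O)c2nc3ccccc3[nH]2)c1)c1cccc(C(F)(F)F)c1` carries 3-(trifluoromethyl)phenyl, and in this assay compound 2 gives 21500 nM. Compound 3 `COc1cccc(C(=O)Nc2cccc(/C=C/C(=O)c3nc4ccccc4[nH]3)c2)c1` carries 3-methoxyphenyl, and in this assay compound 3 gives 17800 nM, a number lying within the scatter of both compound 2 and compound 1, so no rank among the three follows from it. The steps seen are a 2.2-fold higher number from compound 1 to compound 2 (0.35 log units; beyond the scatter), a 1.8-fold higher number from compound 1 to compound 3 (0.26 log units; within the scatter) and a 1.2-fold lower number from compound 2 to compound 3 (0.08 log units; within the scatter).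

Compound 4 `O=C(Nc1cccc(/C=C/C(=O)c2nc3ccccc3[nH]2)c1)c1cc(Cl)cc(Cl)c1` differs from compound 3 by 3,5-dichlorophenyl in place of 3-methoxyphenyl on a carbonyl carbon. All three measured steps concern this same aryl group on the carbonyl carbon; only one of them crossed the scatter, and modestly. The expected step in this assay is therefore a 1.0-fold lower number from compound 3 to compound 4 (0.02 log units; within the scatter), within the scatter. Compound 4 is estimated at 17000 nM in this assay, with a range of 7000 nM to 40000 nM.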

Compound 4, half-maximal inhibitory concentration: > 100000 nM
Compound 4 ended at the assay's limit; the forecaster's own chance of this, stated with the estimate: 10%; middle value at least 5.8-fold (0.76 log units) from the limit.
By their numbers in this assay, from the lowest: compounds 1, 3 and 2 (each within the scatter of the next, the first and the last beyond it). At a limit, above all of these: compound 4.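

In this assay compound 4 gives > 100000 nM, which is a limit of the assay and not a number. The earlier swaps of the aryl group on this carbonyl carbon stayed close to the scatter, whereas 3,5-dichlorophenyl gives clear steps beyond it: an at least 5.6-fold higher number from compound 3 to compound 4 (0.74 log units; beyond the scatter), an at least 4.6-fold higher number from compound 2 to compound 4 (0.66 log units; beyond the scatter) and an at least 10-fold higher number from compound 1 to compound 4 (1.01 log units; beyond the scatter). This position is therefore not indifferent to the aryl group it carries, although the full size of these steps cannot be read from the limit: the limit of > 100000 nM in this assay, at which 1 of the 4 values shown sits.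

From the compounds shown here alone, whether one chlorine on the phenyl ring is enough for this loss, or both are needed, stays open. Also open, going by these compounds, is how a phenyl ring bearing an amine or a carboxylic acid would read at this position in this assay.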